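This account rests on a few compounds, and the source may have more. Where it says the series, first, only, none or still open, it means among the compounds named here.

Compound 1 `CCN(CC)CCn1c(N)c(-c2nc3ccccc3[nH]2)c2nc(C#N)c(C#N)nc21` is the reference point of the set. In a functional assay on HeLa cells (Homo sapiens) for antiproliferative activity, read by MTT assay, with a stated time of 48 h (on this read-out lower numbers stand for stronger inhibition and higher numbers for weaker inhibition), compound 1 gives 11600 nM. Compound 2 `CN(C)CCCn1c(N)c(-c2nc3ccccc3[nH]2)c2nc(C#N)c(C#N)nc21` carries the change ((dimethylamino)methyl in place of diethylamino on a saturated chain carbon, two bonds along the chain from an aromatic nitrogen); the step is a 2.2-fold higher number from compound 1 to compound 2 (0.35 log units; beyond the scatter), and in this assay compound 2 gives 25900 nM. Compound 3 `CCN(CC)CCn1c(N)c(-c2nc3ccccc3n2C)c2nc(C#N)c(C#N)nc21` differs from compound 1 in the core, the change being (methyl in place of hydrogen on an aromatic nitrogen), and the step is an at least 4.3-fold higher number from compound 1 to compound 3 (0.63 log units; beyond the scatter). In this assay compound 3 gives > 50000 nM; this is a limit of the assay and not a number, as recorded by the limit of > 50000 nM in this assay, at which 1 of the 3 values shown sits.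

Compound 4 `CN(C)CCCn1c(N)c(-c2nc3ccccc3n2C)c2nc(C#N)c(C#N)nc21` is not yet measured. It differs from compound 3 by (dimethylamino)methyl in place of diethylamino on a saturated chain carbon, two bonds along the chain from an aromatic nitrogen. The place wording is the same, word for word, as for the change from compound 1 to compound 2, so this is the same change, now made on the core of compound 3 rather than that of compound 1; the two cores differ by the methyl in place of hydrogen on an aromatic nitrogen described above. Within the data shown here, the one measured instance of the change gave a 2.2-fold higher number from compound 1 to compound 2 (0.35 log units; beyond the scatter). The step from compound 3 to compound 4 is expected to be of like size, a step that the limit leaves unreadable from compound 3 to compound 4, resting on the measured step of a 2.2-fold higher number from compound 1 to compound 2 (0.35 log units; beyond the scatter). Compound 4 is therefore expected to sit at or past the assay limit, with an estimate of 110000 nM and a range from 50000 nM to 300000 nM.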

Compound 4, half-maximal inhibitory concentration: 4320 nM
Beside the measured number, compound 4's estimate is 25-fold (1.41 log units) above it; measured number outside the range, below it.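

With the methyl in place of hydrogen on an aromatic nitrogen, the change from 2-(diethylamino)ethyl to 3-(dimethylamino)propyl gives an at least 11-fold lower number from compound 3 to compound 4 (1.06 log units; beyond the scatter) in this assay, so this change does not carry over between the two cores in size or in direction: the same change on two cores in this assay, a 2.2-fold higher number (0.35 log units; beyond the scatter) from compound 1 to compound 2 and an at least 11-fold lower number (1.06 log units; beyond the scatter) from compound 3 to compound 4, at least 25-fold (1.41 log units) apart, beyond the scatter of two such steps

Read the other way, the methyl on the aromatic nitrogen also depends on the chain it is paired with, giving a 6.0-fold lower number from compound 2 to compound 4 (0.78 log units; beyond the scatter) with 3-(dimethylamino)propyl in place: the same change on two cores in this assay, an at least 4.3-fold higher number (0.63 log units; beyond the scatter) from compound 1 to compound 3 and a 6.0-fold lower number (0.78 log units; beyond the scatter) from compound 2 to compound 4, at least 25-fold (1.41 log units) apart, beyond the scatter of two such steps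

Compound 3 gives > 50000 nM, a limit of the assay and not a number, so the full size of these gaps stays unread, and the four compounds show that the two changes do not add up in this series without showing why.

As far as these compounds go, the change alters the chain length and the groups on the amine together, so it remains open which of the two goes with the reversal; 2-(dimethylamino)ethyl and 3-(diethylamino)propyl on each core would separate them. From the compounds shown here alone, it also remains open whether an ethyl on the same aromatic nitrogen would behave as the methyl does.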